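This account rests on a few compounds, and the source may have more. Where it says the series, first, only, none or still open, it means among the compounds named here.

Three compounds have been measured in an assay on HL-60 cells for agonist activity at vitamin D3 receptor (Homo sapiens), read by microscopy, with a stated time of 96 h; on this read-out higher numbers stand for an effect only at larger amounts of compound and lower numbers for an effect already at smaller amounts:

Compound 1 `CC[C@@H](C)[C@H](NC(=O)c1ccc(C(CC)(CC)c2ccc(OCC(=O)C(C)(C)C)c(C)c2)n1CC)C(=O)OC` gives 590 nM.
Compound 2 `CCOC(=O)CN(C)C(=O)c1ccc(C(CC)(CC)c2ccc(OCC(=O)C(C)(C)C)c(C)c2)n1CC` gives only a limit of the assay, > 50000 nM.
Compound 3 `CCn1c(C(=O)NCCN(C)C)ccc1C(CC)(CC)c1ccc(OCC(=O)C(C)(C)C)c(C)c1` gives 77 nM.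

All three share the same core and differ only in the group carried on the amide carbonyl. Compound 3 stands at the lowest of the two numbers shown; the step of a 7.7-fold lower number from compound 1 to compound 3 (0.88 log units; beyond the scatter) lies beyond the scatter, and the step of an at least 640-fold lower number from compound 2 to compound 3 (2.81 log units; beyond the scatter) is larger still, starting as it does from the limit of > 50000 nM in this assay, at which 1 of the 3 values shown sits.

Compound 4 `CCn1c(C(=O)NCCCN(C)C)ccc1C(CC)(CC)c1ccc(OCC(=O)C(C)(C)C)c(C)c1` differs from compound 3 only in (dimethylamino)methyl in place of dimethylamino on a saturated chain carbon, two bonds along the chain from an amide-type nitrogen. Going by the values given here, none of the measured steps bears directly on this: both steps into compound 3 exchange the whole amide substituent, and they show that this part of the molecule weighs heavily in this assay, but neither tests a chain lengthened by a single carbon while the dimethylamino end is kept. Such a change is far smaller than those measured, so no step beyond the scatter is expected in either direction. Compound 4 is therefore expected to show a 1.2-fold higher number from compound 3 to compound 4 (0.07 log units; within the scatter). Compound 4 is estimated at 90 nM, between 30 nM and 300 nM.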

Compound 4, half-maximal effective concentration: 96 nM
Beside the measured number, compound 4's estimate is 1.1-fold (0.03 log units) below it; low and high end bracket the measured number.
By their numbers in this assay, from the lowest: compounds 3 and 4 (each within the scatter of the next); then compound 1. At a limit, above all of these: compound 2.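

In this assay the chain on the amide-type nitrogen can go from 2-(dimethylamino)ethyl to 3-(dimethylamino)propyl with no readable change: the result is a 1.2-fold higher number from compound 3 to compound 4 (0.10 log units; within the scatter) and so this position does not hang on that exact chain length. The earlier large steps exchanged the whole amide substituent, and the new chain keeps the gap to the ester-bearing group, with a 6.1-fold lower number from compound 1 to compound 4 (0.79 log units; beyond the scatter) on replacing 1-(methoxycarbonyl)-2-methylbutyl. The wider step of an at least 520-fold lower number from compound 2 to compound 4 (2.71 log units; beyond the scatter) starts from compound 2, whose value is a limit and not a number: the limit of > 50000 nM in this assay, at which 1 of the 4 values shown sits.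

The compounds shown leave open how far this tolerance reaches, since a longer chain such as 4-(dimethylamino)butyl or a shorter one such as (dimethylamino)methyl would test its limits in each direction. They also leave open whether the dimethylamino end itself counts, which a primary amine, a carboxylic acid or a plain propyl chain with no nitrogen at that end would help to settle.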